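Swapping the Phenol Ring: From Compound 1 to Compound 4

The source may hold more compounds than are shown below. What is called first, only, known or untested is meant among the compounds shown, and "the series" means these compounds.

Of the compounds shown here, three built on a shared core have been tested in a functional assay on RPMI8266 cells (Homo sapiens) for inhibition; on this read-out higher numbers stand for weaker inhibition of growth and lower numbers for stronger inhibition of growth. Compound 1 `COc1cc(/C=C/C(=O)c2cccc(-n3cc(-c4ccc(Cl)cc4)[nH]c3=O)c2)ccc1O` gives 1330 nM in this assay, which puts it second highest of the three numbers. Its closest neighbour is compound 3 `COc1cc(/C=C/C(=O)c2cccc(-n3cc(-c4ccccc4)[nH]c3=O)c2)ccc1O`, which in this assay gives 1670 nM. The furthest is compound 2 `COc1cc(/C=C/C(=O)c2cccc(-n3cc(-c4ccccc4)[nH]c3=O)c2)cc(OC)c1OC`, which in this assay gives 620 nM, a number that lies beyond the scatter from compound 1.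

Among the compounds with values here, the only single-change step among the measured compounds is a 1.3-fold higher number from compound 1 to compound 3 (0.10 log units; within the scatter), a change on the aromatic ring at the far end of the core from the one altered here.

Compound 4 `O=C(/C=C/c1cccc(O)c1)c1cccc(-n2cc(-c3ccc(Cl)cc3)[nH]c2=O)c1` has not yet been measured. It differs from compound 1 by 3-hydroxyphenyl in place of 4-hydroxy-3-methoxyphenyl on a double-bonded chain carbon bound to a double-bonded chain carbon. Within the data shown here, no measured step touches this part of the molecule, so the step from compound 1 to compound 3 says nothing directly about it; the gap between compound 2 and compound 3 involves a different set of groups on the same ring and cannot be taken as a guide either. The expectation is therefore a step from compound 1 to compound 4 of a 1.2-fold higher number from compound 1 to compound 4 (0.08 log units; within the scatter), that is no change beyond the scatter. For compound 4 the estimated value in this assay is 1600 nM, within a range from 600 nM to 4500 nM.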

Compound 4, concentration for 50% growth inhibition: 1550 nM
For compound 4 the middle estimate is 1.0-fold (0.01 log units) above the measured one, and the stated range covers the measured number.
By their numbers in this assay, from the lowest: compound 2; then compounds 1, 4 and 3 (each within the scatter of the next).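

Within the data shown here, the swap at this position, 3-hydroxyphenyl in place of 4-hydroxy-3-methoxyphenyl on a double-bonded chain carbon bound to a double-bonded chain carbon, gives a 1.2-fold higher number from compound 1 to compound 4 (0.07 log units; within the scatter) in this assay, the first measured step at this end of the molecule. Growth inhibition therefore holds within the scatter when the methoxy group is removed and the hydroxy group sits elsewhere on the ring, even though the entering group has fewer heavy atoms and fewer hydrogen-bond acceptors, with the same count of hydrogen-bond donors. No measurement shown here explains why the number holds, so this remains an observation about the pair alone.

Because two features of the ring change together in this single step, the compounds shown leave open what each does alone, including whether opposite contributions could cancel. They also leave open whether this position would hold its number with a quite different group on the ring, such as an amine or a carboxylic acid in place of the hydroxy group.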